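A few compounds are considered here, and "the series" means these few. Any claim that something is new, unique, unknown or untested is made for them only; others in the source may bear on it.

Of the compounds shown here, three have been measured in an ADME assay on a cell-free system (plasma, Homo sapiens) for metabolic stability; on this read-out higher numbers stand for a longer-lived compound and lower numbers for a shorter-lived compound. Compound 1, with the structure `CCOC(=O)CNC(=O)OCOC(=O)c1cccnc1`, gives 0.00717 h. Compound 2, with the structure `O=C(OC[C@H]1O[C@@H](n2cc(F)c(=O)[nH]c2=O)C[C@@H]1OC(=O)[C@@H]1CCCN1)[C@@H]1CCCN1`, gives 0.1 h. Compound 3, with the structure `Cc1cn([C@H]2C=C[C@@H](COC(=O)CNC(=O)c3ccncn3)O2)c(=O)[nH]c1=O`, gives 1 h. Among these three numbers compound 1 has the lowest, and the gaps to both other compounds are beyond the usual scatter of this assay, so compound 1 is the shortest-lived of the three; compound 2 comes nearest to it and compound 3 lies furthest away.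

Compound 4, with the structure `CCOC(=O)CNC(=O)OCOC(=O)c1ccccc1`, has not yet been measured in this assay. It differs from compound 1 in one place: phenyl in place of pyridin-3-yl on a carbonyl carbon. Within the data shown here, nothing in the measured set shows what such a change does in this assay, so no step of a known size can be borrowed. Compound 4 is therefore expected to stay close to compound 1, with a step of a 1.4-fold higher number from compound 1 to compound 4 (0.14 log units; within the scatter) that is not expected to reach beyond the scatter. The estimate for compound 4 in this assay is 0.01 h, within a range from 0.003 h to 0.04 h.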

Compound 4, half-life: 0.004 h
For compound 4 the middle estimate is 2.5-fold (0.40 log units) above the measured one; the range from low to high includes it.
By their numbers in this assay, from the lowest: compounds 4 and 1 (each within the scatter of the next); then compound 2; then compound 3.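

In this assay, the first step readable at this position, on a carbonyl carbon whose other neighbour is an oxygen next to a carbonyl group, is phenyl in place of pyridin-3-yl, and it amounts to a 1.8-fold lower number from compound 1 to compound 4 (0.25 log units; within the scatter). The ring nitrogen, counted as a hydrogen-bond acceptor in pyridin-3-yl, can therefore be exchanged for carbon here without a difference that can be told apart from repeat scatter, and the rest of compound 1 stays the same in compound 4. Nothing available explains why this pair of compounds behaves this way.

A single pair cannot show whether other groups in this place would also leave the half-life within the scatter. Cyclohexyl, or a phenyl ring carrying an amine or a carboxylic acid, remains an open case at this position.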